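Isopropyl on the Urea Nitrogen: No Gain Expected

The source may report more compounds than this note shows. Statements on the series, on what has been measured and on what is new or still open speak of the compounds shown alone.

Compound 1 `CC(C)NC(=O)N1CCN(C(=S)SCc2cn(Cc3ccc(Cl)cc3)nn2)CC1` and compound 2 `Cc1ccc(Cn2cc(CSC(=S)N3CCN(C(N)=O)CC3)nn2)cc1` differ in more than one place and share a common core. In a functional assay on MCF7 cells (Homo sapiens) for cytotoxicity, read by MTT assay, with a stated time of 72 h (a lower number here means a stronger inhibitor, a higher number a weaker inhibitor), compound 1 reaches only the limit of the measurement, > 128000 nM. In this assay compound 2 likewise reaches only a limit, > 128000 nM. Compound 2 thus sits where both measured values sit, at the limit of > 128000 nM in this assay, at which 2 of the 2 values shown sit. Compound 3 `Cc1ccc(Cn2cc(CSC(=S)N3CCN(C(=O)NC(C)C)CC3)nn2)cc1` carries isopropyl in place of hydrogen on an amide-type nitrogen, isopropyl in place of hydrogen on an amide-type nitrogen. With both known values at a limit, no step beyond the scatter is expected, and the estimated step from compound 2 to compound 3 is a number no higher from compound 2 to compound 3 (the limit leaves the size open). Compound 3 is expected at 128000 nM, within a range from 60000 nM to 300000 nM.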

Compound 3, half-maximal inhibitory concentration: 4630 nM
For compound 3 the middle estimate is 28-fold (1.44 log units) above the measured one; measured number outside the range, below it.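

On the amide-type nitrogen, isopropyl in place of hydrogen makes a clear difference in this assay, with an at least 27-fold lower number from compound 2 to compound 3 (1.44 log units; beyond the scatter). With isopropyl already in place, methyl in place of chloro on an aromatic carbon also counts, with an at least 27-fold lower number from compound 1 to compound 3 (1.44 log units; beyond the scatter). Isopropyl alone is thus not enough: compound 1 carries it, and its > 128000 nM is a limit of the assay.

From the compounds shown here alone, whether a longer chain or a cyclohexyl group on that nitrogen would do as well stays open, as does the effect of methoxy in place of the methyl. Going by these compounds, the full size of both steps is also open, since each starts from a limit.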